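A few compounds are considered here, and "the series" means these few. Any claim that something is new, unique, unknown or untested is made for them only; others in the source may bear on it.

Measured so far in a functional assay on HCT-116 cells (Homo sapiens) for antiproliferative activity, read by MTT assay, with a stated time of 48 h (on this read-out higher numbers stand for weaker inhibition and lower numbers for stronger inhibition), are two compounds
- compound 1 `COc1ccc(N(C)c2ccnc(Cl)n2)cc1Cl` with 1170 nM
- compound 2 `COc1ccc(N(C)c2ccnc(Cl)n2)cc1OCCBr` with 5670 nM

Compound 2, at 5670 nM, holds the higher of the two numbers, which makes it the weaker inhibitor of the pair, and the gap lies beyond the usual scatter. The next compound, compound 3 `COc1ccc(N(C)c2ccnc(Cl)n2)cc1OCCCBr`, has no number yet. The change from compound 2 is bromomethyl in place of bromo on a saturated chain carbon, two bonds along the chain from an oxygen on an aromatic ring, which places bromomethyl in place of bromo on a saturated chain carbon, two bonds along the chain from an oxygen on an aromatic ring. Read one bond further out, this is 2-bromoethoxy to 3-bromopropoxy.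

Among the compounds with values here, only one measured step bears on this. That step, a 4.8-fold higher number from compound 1 to compound 2 (0.69 log units; beyond the scatter), was modest and swapped chloro for 2-bromoethoxy on an aromatic carbon. Within the data shown here, the new change only lengthens that same chain, so a smaller step seems likely, and no compound pair yet shows the effect of chain length or its direction. The expected step is a 1.1-fold lower number from compound 2 to compound 3 (0.05 log units; within the scatter), so no clear shift beyond the scatter is expected. For compound 3 the estimate is 5000 nM, with an expected range from 1800 nM to 14000 nM in this assay.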

Compound 3, half-maximal inhibitory concentration: 1970 nM
Compound 3: middle estimate off by 2.5-fold (0.40 log units), on the high side, and the stated range covers the measured number.
By their numbers in this assay, from the lowest: compounds 1 and 3 (each within the scatter of the next); then compound 2.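

In this assay this position responds to the length of the chain: going from 2-bromoethoxy to 3-bromopropoxy gives a 2.9-fold lower number from compound 2 to compound 3 (0.46 log units; beyond the scatter), a real shift towards stronger inhibition rather than repeat-to-repeat noise. The comparison with the chloro group adds a second point, since replacing chloro with 3-bromopropoxy gives a 1.7-fold higher number from compound 1 to compound 3 (0.23 log units; within the scatter), which stays within the scatter, so the loss seen with 2-bromoethoxy does not carry over to the longer chain and a chain at this position need not weaken inhibition. Nothing available here explains why the two chains differ.

Two chain lengths show a difference but not a trend, so the compounds shown cannot tell whether a longer chain, such as bromobutoxy, would keep the number down or push it back up. They also leave open whether the bromo group itself matters, which a chain of the same length carrying an amine or a hydroxyl group in place of the bromo would help to settle.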